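Swapping an amide for an amine on the anilino nitrogen

This account rests on a few compounds, and the source may have more. Where it says the series, first, only, none or still open, it means among the compounds named here.

Measured so far:
- compound 1, `Cc1nc2ccc(CN(CC(N)=O)c3ccc(C(=O)N[C@@H](CCC(=O)O)C(=O)O)c(F)c3)cc2c(=O)[nH]1`: 1340 nM
- compound 2, `C#CCN(Cc1ccc2nc(C)[nH]c(=O)c2c1)c1ccc(C(=O)N[C@@H](CCC(=O)O)C(=O)O)cc1F`: 1430 nM

Both compounds share one core and differ only in the group carried on the nitrogen attached to the aromatic ring. In an assay on isolated protein for inhibition of Thymidylate synthase (Mus musculus) (a higher number here means a weaker inhibitor, a lower number a stronger inhibitor), compound 1 gives 1340 nM, and compound 2 gives 1430 nM. Compound 1 has the lower of the two numbers, but the gap to compound 2 lies within the scatter of the measurement, so the two cannot be told apart on this evidence.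

Compound 3, `Cc1nc2ccc(CN(CCN)c3ccc(C(=O)N[C@@H](CCC(=O)O)C(=O)O)c(F)c3)cc2c(=O)[nH]1`, is the next variation. Compared with compound 1 the change is aminomethyl in place of carbamoyl on a saturated chain carbon bound to a nitrogen on an aromatic ring, so the chain ends in an amine rather than an amide. Among the compounds with values here, no measured pair shows what such a swap does here, so there is no direct precedent to lean on. With the two known substituents behaving alike, the expectation for the step from compound 1 to compound 3 in this assay is a 1.3-fold higher number from compound 1 to compound 3 (0.13 log units; within the scatter), a modest weakening at most, not clearly beyond the scatter. Compound 3 is therefore expected to give about 1800 nM, with a range from 600 nM to 5400 nM.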

Compound 3, half-maximal inhibitory concentration: 11700 nM
Beside the measured number, compound 3's estimate is 6.5-fold (0.81 log units) below it; the whole stated range lies below it.
By their numbers in this assay, from the lowest: compounds 1 and 2 (each within the scatter of the next); then compound 3.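

In this assay, replacing carbamoyl with aminomethyl on a saturated chain carbon bound to a nitrogen on an aromatic ring gives an 8.7-fold higher number from compound 1 to compound 3 (0.94 log units; beyond the scatter), a step beyond the scatter and the first single-place change readable at this position. It shows that inhibition depends on which group ends this chain, even though the two groups have equal counts of hydrogen-bond donors and acceptors, so those counts alone do not predict the result. No measurement here explains why compound 3 is the weaker inhibitor.

The change swaps the carbonyl-bearing carbamoyl end for a chain ending in an amine, and this single pair cannot show whether losing the carbonyl or gaining the amine matters more. Going by these compounds, a 2-hydroxyethyl group, a carboxylic acid or a longer chain ending in an amine on the same nitrogen of the core of compound 1 would each test a different part of that question, and their effects remain open.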